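A Fluoro-to-Amino Change on the 4-Fluorophenyl Ring

The compounds below may be only part of what the source reports. "The series", "measured", "known", "first", "only" and "open" are said of these compounds alone.

In a functional assay on MCF7 cells (Homo sapiens) for cytotoxicity, read by MTT assay, with a stated time of 96 h (on this read-out lower numbers stand for stronger inhibition and higher numbers for weaker inhibition), compound 3 `COc1cc(C(=O)c2cn(-c3ccc(F)cc3)cc2-c2ccccc2F)cc(OC)c1OC` gives 39 nM. That number lies within the scatter of compound 1 `COc1cc(C(=O)c2cn(-c3ccc(N)cc3)cc2-c2ccccc2)cc(OC)c1OC`, which gives 35 nM, and sits higher than that of compound 2 `COc1cc(C(=O)c2cn(-c3cccc(N)c3)cc2-c2ccccc2F)cc(OC)c1OC`, which gives 17 nM. The next structure, compound 4 `COc1cc(C(=O)c2cn(-c3ccc(N)cc3)cc2-c2ccccc2F)cc(OC)c1OC`, differs from compound 3 at one place: amino in place of fluoro on an aromatic carbon. Seen as a change of the whole ring, 4-fluorophenyl becomes 4-aminophenyl.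

For the measured compounds named here, one measured step bears directly on this change: a 2.3-fold higher number from compound 2 to compound 3 (0.36 log units; beyond the scatter). It is modest, and it replaces 3-aminophenyl with 4-fluorophenyl. Read backwards, it points toward a lower number when an amino-bearing ring returns, but it starts from 3-aminophenyl rather than 4-aminophenyl. Compound 1 does carry 4-aminophenyl and gives 35 nM, yet it differs from compound 3 at a second place too, so it does not isolate this change. A modest move toward a lower number is therefore expected in this assay. The estimated change is a 2.0-fold lower number from compound 3 to compound 4 (0.29 log units; within the scatter). For compound 4 the estimated value is 20 nM, with an expected range from 8 nM to 45 nM.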

Compound 4, half-maximal inhibitory concentration: 28 nM
Beside the measured number, compound 4's estimate is 1.4-fold (0.15 log units) below it, within the range that was stated.
By their numbers in this assay, from the lowest: compounds 2, 4, 1 and 3 (each within the scatter of the next, the first and the last beyond it).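

The step of a 1.4-fold lower number from compound 3 to compound 4 (0.14 log units; within the scatter) in this assay lies within the scatter, so at this place, para to a large group, the assay does not separate amino from fluoro on the shared core. The step of a 1.6-fold higher number from compound 2 to compound 4 (0.22 log units; within the scatter) also lies within the scatter, which means that 4-aminophenyl and 3-aminophenyl cannot be told apart here, even though the earlier step of a 2.3-fold higher number from compound 2 to compound 3 (0.36 log units; beyond the scatter) lies beyond it and 3-aminophenyl and 4-fluorophenyl can. For the compounds shown here, the step of a 1.3-fold lower number from compound 1 to compound 4 (0.10 log units; within the scatter) gives the first one-place comparison for fluoro in place of hydrogen on an aromatic carbon with 4-aminophenyl on the aromatic nitrogen, and it too lies within the scatter, so that change leaves no reading that can be told from repeat measurement in these compounds.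

Nothing available here bears on what lies behind these readings. Still open, from the compounds shown here alone, is whether a hydroxyl, a methoxy, a dimethylamino or an acetamido group at this same place on the ring would read apart from amino and fluoro in this assay.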